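Cycloalkyl pivalamide series: cytotoxicity sits at the ceiling

A few compounds are considered here, and "the series" means these few. Any claim that something is new, unique, unknown or untested is made for them only; others in the source may bear on it.

Measured so far:
compound 1 `CC1CCCCC1N(CCCCCCN1C[C@H](O)[C@@H](O)[C@H](O)[C@H]1CO)C(=O)C(C)(C)C` gives > 500000 nM
compound 2 `CC(C)(C)C(=O)N(CCCCCCN1C[C@H](O)[C@@H](O)[C@H](O)[C@H]1CO)C1CC1` gives > 500000 nM

In an ADME assay on BHK cells (Mesocricetus auratus) for cytotoxicity, read by MTT assay (on this read-out higher numbers stand for lower toxicity in this test and lower numbers for higher toxicity in this test), both values are limits of the assay, not numbers. For compound 2 the reading of > 500000 nM is a limit only. For the measured compounds named here, the one measured step, a step that the two limits leave unreadable from compound 1 to compound 2, is therefore not readable in size or direction; the only evidence is the limit of > 500000 nM in this assay, at which 2 of the 2 values shown sit.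

Compound 3 `CC(C)(C)C(=O)N(CCCCCCN1C[C@H](O)[C@@H](O)[C@H](O)[C@H]1CO)C1CCCC1` has not yet been measured. It differs from compound 2 by cyclopentyl in place of cyclopropyl on an amide-type nitrogen. Going by the values given here, no measured step bears directly on this change, and the single step recorded cannot be read. Given that compound 2 stands at the limit with > 500000 nM, the expectation is that compound 3 again returns no number beyond the scatter, and the step of a number no higher from compound 2 to compound 3 (the limit leaves the size open) is estimated as flat. The estimate for compound 3 in this assay is 500000 nM, with a range from 250000 nM to 1000000 nM.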

Compound 3, half-maximal cytotoxic concentration: > 500000 nM
Compound 3 was reported as a limit; the forecaster's own chance of this, stated with the estimate: 85%; the middle value lies on the limit itself.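

Compound 1, compound 2 and compound 3 each give only a limit in this assay, so no step among them can be read: the limit of > 500000 nM in this assay, at which 3 of the 3 values shown sit.

The compounds shown leave open whether the group on the amide-type nitrogen changes the read-out in this assay at all.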